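Piperidinyl to Morpholinyl Swap on Two Related Cores

The source may hold more compounds than are shown below. What is called first, only, known or untested is meant among the compounds shown, and "the series" means these compounds.

Compound 1 `COc1ccc(-n2nc(CCC(=O)N3CCCCC3)cc2-c2ccc(Cl)cc2)nn1` and compound 2 `COc1ccc(-n2nc(CCC(=O)N3CCOCC3)cc2-c2ccc(Cl)cc2)nn1` share one core and differ in a single place. In a functional assay on a cell-free system (Platelet, plasma, Homo sapiens) for inhibition, read by turbidimetry, with a stated time of 3 min (on this read-out higher numbers stand for weaker inhibition and lower numbers for stronger inhibition), compound 1 gives 920 nM, while compound 2 gives 1080 nM. The change between them is morpholin-4-yl in place of piperidin-1-yl on a carbonyl carbon, and it produced the step of a 1.2-fold higher number from compound 1 to compound 2 (0.07 log units; within the scatter).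

Compound 3 `COc1ccc(-n2nc(C(=O)N3CCCCC3)cc2-c2ccc(Cl)cc2)cc1` is built on a second core; the difference between the two cores is not broken down here. In this assay compound 3 gives 7.9 nM, the lowest of the three numbers, and its steps to compound 1 and to compound 2 are both beyond the scatter.

Compound 4 `COc1ccc(-n2nc(C(=O)N3CCOCC3)cc2-c2ccc(Cl)cc2)cc1` has not yet been measured. It differs from compound 3 by morpholin-4-yl in place of piperidin-1-yl on a carbonyl carbon. Among the measured compounds shown here, this is the same kind of change as the one from compound 1 to compound 2, but not the same: in compound 1 the carbonyl carbon has a saturated chain carbon as its other neighbour, whereas in compound 3 that neighbour is an aromatic carbon.

Because the earlier step of a 1.2-fold higher number from compound 1 to compound 2 (0.07 log units; within the scatter) stayed within the scatter, the expected step of a 1.3-fold higher number from compound 3 to compound 4 (0.10 log units; within the scatter) is small as well. The expectation rests on a single precedent made on a different core, so the range is kept wide. Compound 4 is therefore estimated to give 10 nM in this assay, with a range from 4 nM to 30 nM.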

Compound 4, half-maximal inhibitory concentration: 7.3 nM
For compound 4 the middle estimate is 1.4-fold (0.14 log units) above the measured one, and the stated range covers the measured number.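

In this assay, putting morpholin-4-yl in place of piperidin-1-yl on the carbonyl carbon again leaves the read-out within the usual scatter, with a 1.1-fold lower number from compound 3 to compound 4 (0.03 log units; within the scatter) on the second core, so this ring swap was tolerated on both cores shown. Set side by side, the two steps do not differ, and the change carried over from one core to the other: the same change on two cores in this assay, a 1.2-fold higher number (0.07 log units; within the scatter) from compound 1 to compound 2 and a 1.1-fold lower number (0.03 log units; within the scatter) from compound 3 to compound 4, 1.3-fold (0.10 log units) apart, within the scatter of two such steps. Among the compounds shown here, this rests on only two pairs, however, so it does not show that the swap would pass as quietly on any other core, and it says nothing about why the piperidin-1-yl and morpholin-4-yl compounds read alike, or about how either pair would behave in a different assay.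

The compounds shown leave open whether the position tolerates any six-membered ring on the carbonyl carbon or only these two, since a piperazin-1-yl ring, with its second nitrogen, would be a sharper test than the oxygen of morpholin-4-yl. They also leave open what a smaller pyrrolidin-1-yl ring or an open-chain diethylamino group would do in that same place.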